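The source may hold more compounds than are shown below. What is called first, only, known or untested is meant among the compounds shown, and "the series" means these compounds.

Measured so far in a functional assay on U-251 cells (Homo sapiens) for inhibition, read by sulforhodamine B assay, with a stated time of 48 h, tested at 10 uM; a higher number here means more inhibition at the concentration tested (going by the name of the read-out), a lower number less inhibition:

Compound 1 `c1ccc(-c2cn3ccnc3c(-c3ccc4ncn(C5CCCCC5)c4c3)n2)cc1` gives 37.3%.
Compound 2 `c1cn2cc(-c3ccsc3)nc(-c3ccc4ncn(C5CCCCC5)c4c3)c2n1` gives 6.09%.
Compound 3 `Brc1ccc(-c2cn3ccnc3c(-c3ccc4ncn(C5CCCCC5)c4c3)n2)cc1` gives 23.7%.

Compound 1 stands highest of these three numbers in this assay, and both other compounds lie beyond the scatter below it. The step of a number 31.2 percentage points lower from compound 1 to compound 2 (beyond the scatter) is large, whereas a number 13.6 percentage points lower from compound 1 to compound 3 (beyond the scatter) is modest, and a number 17.6 percentage points higher from compound 2 to compound 3 (beyond the scatter) is modest in the other direction.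

Compound 4 `FC(F)(F)c1cccc(-c2cn3ccnc3c(-c3ccc4ncn(C5CCCCC5)c4c3)n2)c1` differs from compound 1 in one place: trifluoromethyl in place of hydrogen on an aromatic carbon. Within the data shown here, the step that bears most directly on this is the one from compound 1 to compound 3, where a group added to the same phenyl ring cost a modest amount of inhibition. On that basis a modest drop in this assay is expected from compound 1 to compound 4, though a step within the scatter cannot be ruled out. Compound 4 is therefore estimated at 27%, between 12% and 42%. The expected step is a number 10.3 percentage points lower from compound 1 to compound 4 (beyond the scatter).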

Compound 4, a percentage reported as inhibition, at one concentration (the size of the read-out at that concentration, not a potency): 5.93%
Compound 4: the middle estimate sits 21.1 percentage points above what was measured, and the stated range ends above it.
By their numbers in this assay, from the lowest: compounds 4 and 2 (each within the scatter of the next); then compound 3; then compound 1.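

In this assay a single trifluoromethyl group on the phenyl ring, meta to a large group, gives a number 31.4 percentage points lower from compound 1 to compound 4 (beyond the scatter) and so costs far more than the bromo group of compound 3 did. Substituted phenyl rings are therefore not interchangeable here, as a number 17.8 percentage points lower from compound 3 to compound 4 (beyond the scatter) shows, although the group and its place change together in that step and cannot be separated. The 3-(trifluoromethyl)phenyl and thiophen-3-yl compounds cannot be told apart, with a number 0.2 percentage points lower from compound 2 to compound 4 (within the scatter) as the comparison, so both replacements for plain phenyl end up equally low.

No measurement here explains why this change costs so much. As far as these compounds go, it remains open whether the loss belongs to trifluoromethyl itself or to its place, and whether a methoxy or an amine on that same carbon would retain the inhibition of compound 1.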